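The compounds below may be only part of what the source reports. "The series", "measured", "known", "first", "only" and "open" are said of these compounds alone.

Measured in an ADME assay on the whole organism (plasma) for pharmacokinetics, with Mus musculus as the target, at a dose of 25 mg/kg by the oral route; a lower number here means less compound in the circulation, a higher number more compound in the circulation at the dose given:
- compound 1 `Nc1nccn2c1c(-c1ccc3ccc(-c4ccccc4)nc3c1F)nc2[C@H]1CC[C@H](C(=O)O)CC1`: 7970 ng.h/mL
- compound 2 `Nc1nccn2c1c(-c1ccc3ccc(-c4ccccc4)nc3c1F)nc2[C@H]1CC[C@H](C(N)=O)CC1`: 3570 ng.h/mL

At 3570 ng.h/mL, compound 2 is the lower of the two measured compounds in this assay. Compound 3 `Nc1nccn2c1c(-c1ccc3ccc(-c4ccccc4)nc3c1F)nc2[C@H]1CC[C@H](C(=O)Nc2nncs2)CC1` differs from it by 1,3,4-thiadiazol-2-yl in place of hydrogen on an amide-type nitrogen. Among the compounds with values here, only one measured step bears on this part of the molecule: a 2.2-fold lower number from compound 1 to compound 2 (0.35 log units; beyond the scatter). Within the data shown here, that step is modest and beyond the scatter, but it offers only a loose guide, since no measured compound carries the entering group. A further modest fall is therefore expected, with wide uncertainty. The expected change is a 1.8-fold lower number from compound 2 to compound 3 (0.25 log units; within the scatter). The estimate for compound 3 is 2000 ng.h/mL, within an expected range of 500 ng.h/mL to 7000 ng.h/mL.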

Compound 3, area under the concentration-time curve: 297 ng.h/mL
Compound 3: the middle estimate sits 6.7-fold (0.83 log units) above what was measured; the measured number lies below the stated range.
By their numbers in this assay, from the lowest: compound 3; then compound 2; then compound 1.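

In this assay, the amide nitrogen proves far more sensitive than the earlier change on the carbonyl carbon suggested: placing 1,3,4-thiadiazol-2-yl there gives a 12-fold lower number from compound 2 to compound 3 (1.08 log units; beyond the scatter) and is a large step, not a modest one. Against the carboxylic acid, the same change gives a 27-fold lower number from compound 1 to compound 3 (1.43 log units; beyond the scatter) and so widens the gap seen before. No evidence here accounts for a fall of this size. The compounds shown leave open whether a methyl group or a phenyl ring on this nitrogen would lower the number as much, or whether the fall is tied to the 1,3,4-thiadiazol-2-yl ring itself.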